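Vinyl sulfone chain ends: from compound 2 to compound 3

The source may hold more compounds than are shown below. What is called first, only, known or untested is meant among the compounds shown, and "the series" means these compounds.

Measured in a functional assay, read by fluorescence and spectrophotometry, with a stated time of 1 h; a higher number here means that more compound is needed for the effect, a lower number that less compound is needed:
- compound 1 `O=S(=O)(/C=C/c1ccc(O)c(O)c1)CC1CCCCO1`: 10800 nM
- compound 2 `O=S(=O)(/C=C/c1ccc(O)c(O)c1)CCCC1CCCC1`: 6300 nM

Among the compounds with values here, only these two compounds have values so far. Compound 2 stands within the scatter of compound 1, so neither stands apart in this assay.

Still unmeasured is compound 3 `C=CCCCCCS(=O)(=O)/C=C/c1ccc(O)c(O)c1`. Its difference from compound 2 is but-3-en-1-yl in place of cyclopentyl on a saturated chain carbon, three bonds along the chain from a sulfonyl sulfur. In words, this is but-3-en-1-yl in place of cyclopentyl on a saturated chain carbon, three bonds along the chain from a sulfonyl sulfur. Cut one bond further out, it reads 2-cyclopentylethyl to hex-5-en-1-yl.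

Within the data shown here, one measured step bears on this change: a 1.7-fold lower number from compound 1 to compound 2 (0.23 log units; within the scatter). That step also altered the group at the end of the chain, with 2-cyclopentylethyl in place of oxan-2-yl, and it stayed within the scatter. Among the measured compounds shown here, it is thin support, as no measured step replaces a ring with an open chain. No step beyond the scatter is therefore expected, in either direction.

The estimated step is a 1.0-fold higher number from compound 2 to compound 3 (0.01 log units; within the scatter). For compound 3 the expected value is 6500 nM, with an estimated range of 3000 nM to 14000 nM.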

Compound 3, half-maximal effective concentration: 7100 nM
Compound 3: middle estimate off by 1.1-fold (0.04 log units), on the low side; low and high end bracket the measured number.
By their numbers in this assay, from the lowest: compounds 2, 3 and 1 (each within the scatter of the next).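

In this assay, the open chain of compound 3 replaces the ring of compound 2 at the saturated chain carbon, three bonds along the chain from a sulfonyl sulfur, with a 1.1-fold higher number from compound 2 to compound 3 (0.05 log units; within the scatter) as the result. Within the data shown here, this shows that at this position, losing the cyclopentyl ring and gaining the terminal double bond of but-3-en-1-yl gives no step beyond the scatter, which no earlier pair could show. The second new comparison, hex-5-en-1-yl in place of oxan-2-yl on a saturated chain carbon bound to a sulfonyl sulfur, gives a 1.5-fold lower number from compound 1 to compound 3 (0.18 log units; within the scatter) and so leaves the three chain ends unseparated in this read-out, and no supporting data on these chain ends are available to account for this.

As far as these compounds go, whether an amine or a carboxylic acid at the chain end, or a much longer chain than hex-5-en-1-yl, would give a step beyond the scatter remains open. Also open, from the compounds shown here alone, is whether the flat result holds on any core other than the one shared by these three compounds.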